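The source may hold more compounds than are shown below. What is called first, only, known or untested is meant among the compounds shown, and "the series" means these compounds.

Measured so far:
Compound 1 `COc1ccc(/C=C/C(=O)/C=C/c2ccc(OCc3cn(CCCCCOc4cc(=O)oc5ccccc45)nn3)c(OC)c2)cc1OC`: 45%
Compound 2 `COc1cc(/C=C/C(=O)/C=C/c2cccc3ccccc23)ccc1OCc1cn(CCCCCOc2cc(=O)oc3ccccc23)nn1`: 42%
Compound 3 `COc1cc(/C=C/C(=O)/C=C/c2cccs2)ccc1OCc1cn(CCCCCOc2cc(=O)oc3ccccc23)nn1`: 31%

In a functional assay on HCT-116 cells (Homo sapiens) for inhibition, read by sulforhodamine B assay, with a stated time of 48 h, tested at 50 uM (on this read-out higher numbers stand for more inhibition of growth at the one concentration tested and lower numbers for less inhibition of growth), compound 3 gives 31%, the lowest of the three numbers, and both other compounds lie above it by more than the usual scatter. The next compound, compound 4 `COc1ccc(/C=C/C(=O)/C=C/c2ccc(OCc3cn(CCCCCOc4cc(=O)oc5ccccc45)nn3)c(OC)c2)cc1`, keeps the rest of the molecule but carries 4-methoxyphenyl in place of thiophen-2-yl on a double-bonded chain carbon bound to a double-bonded chain carbon.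

The measured steps at this same place are the best guide. Replacing 3,4-dimethoxyphenyl with thiophen-2-yl gave a number 14 percentage points lower from compound 1 to compound 3 (beyond the scatter). Replacing naphthalen-1-yl with thiophen-2-yl gave a number 11 percentage points lower from compound 2 to compound 3 (beyond the scatter). By contrast, exchanging the two larger groups gave a number 3 percentage points lower from compound 1 to compound 2 (within the scatter). Among these three compounds, then, only the thiophen-2-yl compound stands apart. The entering group has a six-membered aromatic ring of carbon only, like the group in compound 1, which reached 45%. Going by the values given here, with only three compounds, this remains a thin basis for prediction.

A modest rise is therefore expected, with the estimated step being a number 10 percentage points higher from compound 3 to compound 4 (within the scatter). The estimate for compound 4 is 41%, with an expected range from 31% to 51%.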

Compound 4, percent growth inhibition at one concentration: 35%
Compound 4: middle estimate off by 6 percentage points, on the high side; measured number inside the range.
By their numbers in this assay, from the lowest: compounds 3, 4, 2 and 1 (each within the scatter of the next, the first and the last beyond it).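

In this assay replacing thiophen-2-yl with 4-methoxyphenyl gave a number 4 percentage points higher from compound 3 to compound 4 (within the scatter) and replacing naphthalen-1-yl with 4-methoxyphenyl gave a number 7 percentage points lower from compound 2 to compound 4 (within the scatter) so compound 4 cannot be told apart from either neighbour at this place. Hydrogen in place of methoxy on an aromatic carbon gave a number 10 percentage points lower from compound 1 to compound 4 (within the scatter) while the earlier change still reads as a number 14 percentage points lower from compound 1 to compound 3 (beyond the scatter) so compound 4 lies within the scatter of both ends of a gap that is real, and a six-membered aromatic ring of carbon only does not by itself lift a compound clear of compound 3. Nothing measured here bears on why the numbers fall this way.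

Still open, on these data alone, is whether a plain phenyl, a 4-hydroxyphenyl or a 4-(dimethylamino)phenyl group at this place would give a number beyond the scatter of compound 3 or compound 1. Also open, as far as these compounds go, is how a longer chain in the linker would change growth inhibition, and how these compounds would compare at other concentrations, given that each number here comes from a single one.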